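The source may report more compounds than this note shows. Statements on the series, on what has been measured and on what is new or still open speak of the compounds shown alone.

Measured so far:
Compound 1 `COc1ccc(CN2C(=O)/C(=C\c3ccccc3)c3cc(-c4ccc(OC)cc4)ccc32)cc1`: in a functional assay on K562 cells (Homo sapiens) for antiproliferative activity, read by MTT assay, with a stated time of 48 h (on this read-out lower numbers stand for stronger inhibition and higher numbers for weaker inhibition), compound 1 gives > 10000 nM, which is a limit of the assay and not a number.
Compound 2 `COc1ccc(CN2C(=O)/C(=C\c3ccc(C(F)(F)F)cc3)c3cc(-c4ccc(OC)cc4)ccc32)cc1`: in this assay compound 2 gives 1900 nM.

Compound 2 therefore holds the only number shown in this assay; the one further entry is a limit (the limit of > 10000 nM in this assay, at which 1 of the 2 values shown sits). Within the data shown here, the single measured step is an at least 5.2-fold lower number from compound 1 to compound 2 (0.72 log units; beyond the scatter). Compound 3 `COc1ccc(CN2C(=O)/C(=C\c3ccc(C(C)C)cc3)c3cc(-c4ccc(OC)cc4)ccc32)cc1` differs from compound 2 by isopropyl in place of trifluoromethyl on an aromatic carbon. Among the measured compounds shown here, no measured step covers an exchange of one such group for another at this place; the one step shows only that a group there, rather than hydrogen, went with a lower number. Isopropyl again sets a group rather than hydrogen at that carbon, so the expected step in this assay is none beyond the scatter, leaning if anything toward a somewhat higher number: a 1.5-fold higher number from compound 2 to compound 3 (0.17 log units; within the scatter). Compound 3 is estimated at 2800 nM, with a range from 900 nM to 9000 nM.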

Compound 3, half-maximal inhibitory concentration: > 10000 nM
Compound 3 ended at the assay's limit; the forecaster's own chance of this, stated with the estimate: 15%; middle value at least 3.5-fold (0.55 log units) from the limit.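

In this assay, isopropyl in place of trifluoromethyl at this carbon gives an at least 5.2-fold higher number from compound 2 to compound 3 (0.72 log units; beyond the scatter), so setting a group rather than hydrogen there is not enough by itself to give a measured number, and which group stands there matters. Of the three compounds shown, only compound 2, with its 4-(trifluoromethyl)phenyl, gives a number; no compound shown goes against this, though the series is small. The step from compound 1 to compound 3 cannot be read, both entries being limits of the assay and not numbers: the limit of > 10000 nM in this assay, at which 2 of the 3 values shown sit.

What the compounds shown leave open is whether the gain belongs to trifluoromethyl alone or extends to other groups at this carbon, such as a nitrile, a chlorine atom or a carboxylic acid. Also open, as far as these compounds go, is how a trifluoromethyl group would fare at another carbon of the same ring.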